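This account rests on a few compounds, and the source may have more. Where it says the series, first, only, none or still open, it means among the compounds named here.

Of the compounds shown here, two sharing one core have been measured in a functional assay on HT-29 cells (Homo sapiens) for cytotoxicity, read by MTT assay, with a stated time of 72 h; a higher number here means a weaker inhibitor of growth, a lower number a stronger inhibitor of growth. Compound 1 `CC(C)COC(=O)Nc1ccc([Se]C#N)cc1` gives 8100 nM, and compound 2 `CCCCCCOC(=O)Nc1ccc([Se]C#N)cc1` gives 10700 nM. Within the data shown here, of these two numbers, compound 2 stands highest, with compound 1 its only neighbour, and the gap between them lies within the scatter. Compound 3 `CCOC(=O)Nc1ccc([Se]C#N)cc1` awaits measurement in this assay. It differs from compound 2 by hydrogen in place of butyl on a saturated chain carbon, two bonds along the chain from an oxygen next to a carbonyl group, so the chain on the oxygen next to the carbonyl group shrinks from hexyl to ethyl. Among the measured compounds shown here, the only measured step that bears on this change, also a swap of one alkyl chain for another on that oxygen-bound carbon, moved the number by a 1.3-fold higher number from compound 1 to compound 2 (0.12 log units; within the scatter). On that basis no step beyond the scatter is expected in this assay for compound 3, in either direction. Compound 3 is therefore estimated at 9000 nM, a step of a 1.2-fold lower number from compound 2 to compound 3 (0.08 log units; within the scatter), within the range 3500 nM to 24000 nM.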

Compound 3, concentration for 50% growth inhibition: 9300 nM
The estimate for compound 3 lay 1.0-fold (0.01 log units) below the measured number; the measured number falls inside the stated range.
By their numbers in this assay, from the lowest: compounds 1, 3 and 2 (each within the scatter of the next).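

In this assay, hydrogen in place of butyl on a saturated chain carbon, two bonds along the chain from an oxygen next to a carbonyl group, gives a 1.2-fold lower number from compound 2 to compound 3 (0.06 log units; within the scatter), so going from hexyl to ethyl leaves the number within the scatter. Methyl in place of isopropyl on the saturated chain carbon bound to that oxygen gives a 1.1-fold higher number from compound 1 to compound 3 (0.06 log units; within the scatter), so all three alkyl chains shown here, including the branched chain of compound 1, read alike in this assay. No measurement available here offers a reason for this flat response.

The compounds shown leave open whether a chain longer than hexyl would take the number beyond the scatter. The same question stands for an amine or a carboxylic acid placed on the chain.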